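Changing the Benzyl Ring on a Sulfonamide Growth Inhibitor

A few compounds are considered here, and "the series" means these few. Any claim that something is new, unique, unknown or untested is made for them only; others in the source may bear on it.

Measured compounds:
- compound 1 `O=S(=O)(NCCNCc1cccc2ccccc12)c1cc(C(F)(F)F)cc(C(F)(F)F)c1`; in a functional assay on HPAC cells (Homo sapiens) for inhibition, read by MTT assay, with a stated time of 72 h (on this read-out lower numbers stand for stronger inhibition of growth and higher numbers for weaker inhibition of growth), compound 1 gives 18000 nM
- compound 2 `O=S(=O)(NCCCCNCc1ccc(Br)cc1)c1cc(C(F)(F)F)cc(C(F)(F)F)c1`; compound 2 gives 2000 nM
- compound 3 `O=S(=O)(NCCCNCc1ccc(Cl)c(Cl)c1)c1cc(C(F)(F)F)cc(C(F)(F)F)c1`; compound 3 gives 2500 nM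

Among these three numbers compound 3 stands second highest. Its nearest neighbour is compound 2, and the step of a 1.3-fold higher number from compound 2 to compound 3 (0.10 log units; within the scatter) lies within the scatter of repeated measurements, so the two compounds cannot be told apart on this read-out. Compound 1 is the furthest away, with a clearly higher number than compound 3.

Compound 4 `O=S(=O)(NCCCNCc1ccc(C(F)(F)F)cc1)c1cc(C(F)(F)F)cc(C(F)(F)F)c1` is the next compound. It differs from compound 3 in one place: 4-(trifluoromethyl)phenyl in place of 3,4-dichlorophenyl on a saturated chain carbon bound to an amine nitrogen. For the measured compounds named here, no measured step changes only this ring while keeping the chain length fixed; the single step that touches the ring, from compound 2 to compound 3, also alters the chain and stayed within the scatter. There is therefore no basis for expecting a shift beyond the scatter, and the step of a 1.2-fold higher number from compound 3 to compound 4 (0.08 log units; within the scatter) is expected to be small. For compound 4 the estimated value is 3000 nM, with a range from 1000 nM to 9000 nM.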

Compound 4, concentration for 50% growth inhibition: 2700 nM
Beside the measured number, compound 4's estimate is 1.1-fold (0.05 log units) above it; low and high end bracket the measured number.
By their numbers in this assay, from the lowest: compounds 2, 3 and 4 (each within the scatter of the next); then compound 1.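

In this assay, for the compounds shown here, the step of a 1.1-fold higher number from compound 3 to compound 4 (0.03 log units; within the scatter) is the first to change only the aromatic ring on the saturated chain carbon bound to an amine nitrogen, with the chain itself kept the same. At this place, 3,4-dichlorophenyl and 4-(trifluoromethyl)phenyl cannot be told apart on this read-out, even though the two groups differ in their atoms: 8 heavy atoms with 2 chlorine in the first, and 10 heavy atoms with 3 fluorine in the second. No measurement is available that would explain why these two rings read alike.

The compounds shown leave open whether the ring would still read the same if it carried a carboxylic acid or an amine instead of these halogen-containing groups. They also leave open how a longer chain would read with 4-(trifluoromethyl)phenyl kept in place.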